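The source may report more compounds than this note shows. Statements on the series, on what has been measured and on what is new or still open speak of the compounds shown alone.

In an ADME assay on HEK293 cells (Homo sapiens) for cytotoxicity, read by MTT assay, with a stated time of 72 h (a higher number here means a weaker inhibitor, a lower number a stronger inhibitor), three compounds built on a shared core have been tested so far. Compound 1 `C=CCOc1cc(C2=C(c3cc(OC)c(OC)c(OC)c3)C(=O)C(O)C2)ccc1OC` reads > 100 ug/mL, which is a limit of the assay and not a number. Compound 3 `COc1cc(C2=C(c3cc(C)c(OC)c(C)c3)C(O)CC2=O)cc(OC)c1OC` reads > 100 ug/mL, which is also a limit. Among the measured compounds shown here, compound 2 `COc1ccc(OC)c(C2=C(c3cc(OC)c(OC)c(OC)c3)C(=O)CC2O[SiH2]C(C)(C)C)c1` is the only one with a true number, 9.5 ug/mL.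

The next compound to be tested is compound 4 `COc1ccc(C2=C(c3cc(OC)c(OC)c(OC)c3)C(=O)C(O)C2)cc1Cl`. The change, (chloro in place of allyloxy on an aromatic carbon), puts chloro in place of allyloxy on an aromatic carbon, ortho to a methoxy group. For the measured compounds named here, no measured pair shows what this swap does in this assay, so the expectation starts from compound 1 and its limit of > 100 ug/mL. A small step toward a lower number is expected, perhaps none beyond the scatter, and the assay may again report only a limit. The estimated change is an at least 1.4-fold lower number from compound 1 to compound 4 (0.15 log units; that floor lies within the scatter). Compound 4 is expected at 70 ug/mL, with an estimated range from 20 ug/mL to 200 ug/mL.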

Compound 4, half-maximal inhibitory concentration: > 100 ug/mL
Compound 4 was reported as a limit (the forecaster's own chance of this, stated with the estimate: 55%); middle value at least 1.4-fold (0.15 log units) away from the limit.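

In this assay compound 1 and compound 4 both read as limits and not as numbers, so no step between them can be read, and both sit at the same limit: the limit of > 100 ug/mL in this assay, at which 3 of the 4 values shown sit.

The compounds shown leave open how far, if at all, chloro in place of allyloxy on an aromatic carbon moves the number.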